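The source may report more compounds than this note shows. Statements on the series, on what has been measured and on what is new or still open speak of the compounds shown alone.

Measured compounds:
compound 1 `COC(=O)c1cc(-c2cccc(NC(=O)c3ccc(/C=C/C(=O)c4ccc(C)c(F)c4)cc3)c2)on1` — in an ADME assay on Vero cells (Chlorocebus sabaeus) for cytotoxicity, read by MTT assay, with a stated time of 72 h (on this read-out lower numbers stand for higher toxicity in this test and higher numbers for lower toxicity in this test), compound 1 gives > 50 ug/mL, which is a limit of the assay, not a number.
compound 2 `COC(=O)c1cc(-c2cccc(NC(=O)c3ccc(/C=C/C(=O)c4cccc(OC)c4)cc3)c2)on1` — in this assay compound 2 gives > 100 ug/mL, also a limit rather than a number.

Compound 2 therefore stands at the upper limit of the two values shown, as recorded in the limit of > 100 ug/mL in this assay, at which 1 of the 2 values shown sits; the other value sits at the limit of > 50 ug/mL in this assay, at which 1 of the 2 values shown sits. Among the measured compounds shown here, the one measured step, a step that the two limits leave unreadable from compound 1 to compound 2, is left unreadable by the two limits, so its size is unknown.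

Compound 3 `COC(=O)c1cc(-c2cccc(NC(=O)c3ccc(/C=C/C(=O)c4ccccc4Cl)cc3)c2)on1` is not yet measured. It differs from compound 2 by 2-chlorophenyl in place of 3-methoxyphenyl on a carbonyl carbon. For the measured compounds named here, the only measured step that bears on this position, the change from compound 1 to compound 2 at the same carbonyl carbon, gave no readable size, so no direction beyond the scatter can be expected for a number no higher from compound 2 to compound 3 (the limit leaves the size open); both measured compounds show low toxicity in this assay, and compound 3 is expected to behave alike. The estimate for compound 3 in this assay is 100 ug/mL, with a range from 40 ug/mL to 250 ug/mL, most likely reported again only as a limit.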

Compound 3, half-maximal cytotoxic concentration: > 25 ug/mL
Compound 3 was reported as a limit; the forecaster's own chance of this, stated with the estimate: 75%; the middle value is on the limit's open side.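

In this assay compound 3 gives > 25 ug/mL, a limit of the assay and not a number. Among the compounds shown here, the values of compound 1 and compound 2 are limits too, and no step among compound 1, compound 2 and compound 3 can be read. Left open are the actual half-maximal cytotoxic concentrations of all three compounds and whether they differ at all.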